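The source may hold more compounds than are shown below. What is called first, only, known or untested is meant among the compounds shown, and "the series" means these compounds.

In a functional assay on A549 cells (Homo sapiens) for antiproliferative activity, read by sulforhodamine B assay, with a stated time of 3 days (on this read-out lower numbers stand for an effect already at smaller amounts and higher numbers for an effect only at larger amounts of compound), compound 3 (`CCCCOC1=C(CCC)C(=O)/C(=C(O)/C=C/c2ccccc2)C(=O)C1(CCC)CCC`) gives 7.1 uM and sits within the scatter of compound 1 (`CCCC1=C(OC)C(CCC)(CCC)C(=O)/C(=C(O)\C=C\c2ccccc2)C1=O`) at 3.6 uM as well as of compound 2 (`CCCC1=C(OCCC(C)C)C(CCC)(CCC)C(=O)/C(=C(O)\C=C\c2ccccc2)C1=O`) at 11.3 uM on these numbers. Compound 4 (`CCCC1=C(OCC)C(CCC)(CCC)C(=O)/C(=C(O)\C=C\c2ccccc2)C1=O`) differs from compound 3 by hydrogen in place of ethyl on a saturated chain carbon, two bonds along the chain from an oxygen on an unsaturated carbon (hydrogen in place of ethyl, butoxy to ethoxy). Three steps on the chain at that oxygen bear on this: a 2.0-fold higher number from compound 1 to compound 3 (0.29 log units; within the scatter) and a 1.6-fold lower number from compound 2 to compound 3 (0.20 log units; within the scatter) stay within the scatter while a 3.1-fold higher number from compound 1 to compound 2 (0.50 log units; beyond the scatter) is the only one beyond it. A small move to a lower number is therefore expected in this assay and nothing beyond the scatter. The expected step is a 1.4-fold lower number from compound 3 to compound 4 (0.15 log units; within the scatter) as a working figure. For compound 4 the estimate is 5 uM with an expected range from 2.5 uM to 10 uM in these notes.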

Compound 4, concentration for half-maximal effect: 4.6 uM
Estimate against measurement, compound 4: 1.1-fold (0.04 log units) above; the range from low to high includes it.
By their numbers in this assay, from the lowest: compounds 1, 4, 3 and 2 (each within the scatter of the next, the first and the last beyond it).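

In this assay, butoxy to ethoxy gives a 1.5-fold lower number from compound 3 to compound 4 (0.19 log units; within the scatter), and a 1.3-fold higher number from compound 1 to compound 4 (0.11 log units; within the scatter) also stays within the scatter, so the chains of compounds 1, 3 and 4 are not separated. Compound 2 stands apart from compound 4, with a 2.5-fold lower number from compound 2 to compound 4 (0.39 log units; beyond the scatter), though compound 3 goes against any clean split by staying within the scatter of compound 2. Hydrogen in place of methyl repeats its size: the same change on two cores in this assay, a 1.6-fold lower number (0.20 log units; within the scatter) from compound 2 to compound 3 and a 1.3-fold lower number (0.11 log units; within the scatter) from compound 4 to compound 1, 1.2-fold (0.10 log units) apart, within the scatter of two such steps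

Open, on these data alone, is whether a chain ending in an amine or a carboxylic acid at that oxygen would move the number beyond the scatter. As far as these compounds go, a chain longer than that of compound 2 is equally open.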